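The source may report more compounds than this note shows. Statements on the series, on what has been measured and on what is new or still open speak of the compounds shown alone.

Compound 3 `Cc1cc(NC(=O)Nc2ccc(C(N)=O)cc2)c2ccccc2n1` is one of three analogues that share a core and differ only in one group on an aromatic carbon. In an ADME assay on HepG2 cells (Homo sapiens) for cytotoxicity, with a stated time of 72 h (a higher number here means that more compound is needed for the effect, a lower number that less compound is needed), compound 3 reaches only the limit of the assay, > 25000 nM. Compound 2 `Cc1cc(NC(=O)Nc2ccc(Cl)cc2)c2ccccc2n1`, bearing chloro, likewise gives only a limit in this assay, > 25000 nM. Going by the values given here, compound 1 `CSc1ccc(NC(=O)Nc2cc(C)nc3ccccc23)cc1`, with methylsulfanyl, is the single analogue with a number in this assay, 16000 nM. The step of an at least 1.5-fold higher number from compound 1 to compound 2 (0.19 log units; that floor lies within the scatter) and the step of an at least 1.5-fold higher number from compound 1 to compound 3 (0.19 log units; that floor lies within the scatter) both rest on a limit, and the step that the two limits leave unreadable from compound 2 to compound 3 cannot be read, because of the limit of > 25000 nM in this assay, at which 2 of the 3 values shown sit. Compound 4 `Cc1cc(NC(=O)Nc2ccc(C(F)(F)F)cc2)c2ccccc2n1` carries the change (trifluoromethyl in place of carbamoyl on an aromatic carbon). Among the compounds with values here, no measured step here joins two numbers, so the steps that bear on this change give no direction beyond the scatter. The step of a number no higher from compound 3 to compound 4 (the limit leaves the size open) is therefore expected to be no larger than the scatter. The estimate for compound 4 in this assay is 25000 nM, between 12000 nM and 60000 nM, and compound 4 is expected most likely to be reported again only as a limit.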

Compound 4, half-maximal effective concentration: 23000 nM
For compound 4 the middle estimate is 1.1-fold (0.04 log units) above the measured one; the measured number falls inside the stated range.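

Going by these compounds alone, the first step in this assay that joins two numbers is a 1.4-fold higher number from compound 1 to compound 4 (0.16 log units; within the scatter), so trifluoromethyl in place of methylsulfanyl on this aromatic carbon, para to a large group, gives no difference beyond the scatter. The other two new steps, an at least 1.0-fold lower number from compound 3 to compound 4 (0.03 log units; that floor lies within the scatter) and an at least 1.0-fold lower number from compound 2 to compound 4 (0.03 log units; that floor lies within the scatter), each rest on a limit and show no direction: the limit of > 25000 nM in this assay, at which 2 of the 4 values shown sit. Among the four groups shown at this position, including carbamoyl with its hydrogen-bond donor and acceptor and trifluoromethyl with neither, no printed step goes beyond the scatter.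

As far as these compounds go, the numbers behind the limits of compound 2 and compound 3 stay open, so the size of any step resting on those limits cannot be read. Also open, from the compounds shown here alone, is whether an amine or a carboxylic acid on this aromatic carbon would give a number clearly apart from these.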